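Compound 2 Loses a Chloro Group

The source may report more compounds than this note shows. Statements on the series, on what has been measured and on what is new or still open speak of the compounds shown alone.

In a functional assay on BEAS-2B cells (Homo sapiens) for inhibition, read by MTT assay, with a stated time of 72 h (on this read-out higher numbers stand for weaker inhibition and lower numbers for stronger inhibition), compound 1 (`C=C(c1ccc(Cl)c(Cl)c1)C1COC2(CCCCC2)OO1`) gives 39400 nM while compound 2 (`C=C(c1ccc(Cl)c(Cl)c1Cl)C1COC2(CCCC2)OO1`) gives 11500 nM and so holds the lower of the two numbers, by a gap beyond the usual scatter. Compound 3 (`C=C(c1ccc(Cl)cc1Cl)C1COC2(CCCC2)OO1`) has not yet been measured. It differs from compound 2 by hydrogen in place of chloro on an aromatic carbon. Within the data shown here, no measured pair isolates this change, so only a small move towards weaker inhibition is expected, an estimated step (a 1.6-fold higher number from compound 2 to compound 3 (0.19 log units; within the scatter)) within the usual scatter. In this assay compound 3 is expected at an estimated 18000 nM (range 7000 nM to 45000 nM).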

Compound 3, half-maximal inhibitory concentration: 17400 nM
Estimate against measurement, compound 3: 1.0-fold (0.01 log units) above; low and high end bracket the measured number.
By their numbers in this assay, from the lowest: compounds 2 and 3 (each within the scatter of the next); then compound 1.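

In this assay, hydrogen in place of chloro on an aromatic carbon, ortho to two chloro groups, gives a 1.5-fold higher number from compound 2 to compound 3 (0.18 log units; within the scatter), and this is the only pair shown that isolates the change. At this position, the chloro group can therefore be exchanged for hydrogen without a difference that stands clear of the scatter. No measurement is available to explain this result.

The compounds shown leave open whether an amine, a methoxy group or a nitrile at this position would give a number apart from those of compound 2 and compound 3.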